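A few compounds are considered here, and "the series" means these few. Any claim that something is new, unique, unknown or untested is made for them only; others in the source may bear on it.

Compound 1 `O=C1C=C(N2CCC2)C(=O)c2c1nc1n2[C@H]2OC[C@@H](O)[C@H]2OC1` gives > 16000 nM in a functional assay on MCF7 cells (Homo sapiens) for inhibition, read by sulforhodamine B assay (on this read-out higher numbers stand for weaker inhibition and lower numbers for stronger inhibition), a limit of the assay rather than a number.
Compound 2 `CCc1ccc(NC2=CC(=O)c3c(nc4n3[C@H]3OC[C@@H](O)[C@H]3OC4)C2=O)cc1` gives 8990 nM in this assay.
Compound 3 `CCOc1ccc(NC2=CC(=O)c3c(nc4n3[C@H]3OC[C@@H](O)[C@H]3OC4)C2=O)cc1` gives > 4000 nM in this assay, again a limit and not a number.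

Compound 1 thus stands at the limit of > 16000 nM in this assay, at which 1 of the 3 values shown sits, the weakest-looking end of what is shown, though only as a limit. For the measured compounds named here, the one step among measured compounds, a step that the limit leaves unreadable from compound 2 to compound 3, is itself unreadable and concerns a change on an aromatic carbon, so nothing measured bears on the move to compound 4 `O=C1C=C(N2CCCC2)C(=O)c2c1nc1n2[C@H]2OC[C@@H](O)[C@H]2OC1`, which carries pyrrolidin-1-yl in place of azetidin-1-yl on a double-bonded ring carbon. No step beyond the scatter is expected. Compound 4 is therefore estimated at 20000 nM, between 7000 nM and 60000 nM. This expectation means a step that the limit leaves unreadable from compound 1 to compound 4, most likely reported again only as a limit.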

Compound 4, half-maximal inhibitory concentration: > 16000 nM
Compound 4 gave a limit, no number; the forecaster's own chance of this, stated with the estimate: 65%; the middle value lies beyond the limit too.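

Compound 1 and compound 4 each give only a limit of the assay, so no step can be read between them. The compounds shown leave open whether pyrrolidin-1-yl and azetidin-1-yl differ at all in this assay.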